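This account rests on a few compounds, and the source may have more. Where it says the series, first, only, none or still open, it means among the compounds named here.

Three compounds built on a shared core were measured in a functional assay on PC-3 cells (Homo sapiens) for cytotoxicity, read by MTT assay, with a stated time of 72 h; on this read-out lower numbers stand for stronger inhibition and higher numbers for weaker inhibition. Compound 1 `Cc1cc(=O)n(-c2ccccc2OC(F)(F)F)nc1C(=O)Nc1ccc(Oc2ncnc3c2ccn3C)cc1` gives 5160 nM. Compound 2 `Cc1cc(=O)n(-c2ccccc2C(F)(F)F)nc1C(=O)Nc1ccc(Oc2ncnc3c2ccn3C)cc1` gives 19100 nM, and compound 3 `Cc1cc(=O)n(-c2ccccc2Cl)nc1C(=O)Nc1ccc(Oc2ncnc3c2ccn3C)cc1` gives 16400 nM. Among these three numbers compound 3 stands second highest: the step of a 1.2-fold lower number from compound 2 to compound 3 (0.07 log units; within the scatter) is within the scatter, whereas the steps of a 3.2-fold higher number from compound 1 to compound 3 (0.50 log units; beyond the scatter) and a 3.7-fold higher number from compound 1 to compound 2 (0.57 log units; beyond the scatter) lie beyond it. All three measured steps concern the exchange of one group on an aromatic carbon, and in every case that exchange happens at the same position, away from where compound 4 differs.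

Compound 4 `Cc1cc(=O)n(-c2ccccc2Cl)nc1C(=O)Nc1ccc(Oc2ncnc3c2ccn3C)c(F)c1` differs from compound 3 by fluoro in place of hydrogen on an aromatic carbon. Among the measured compounds shown here, no measured step touches this part of the molecule, so the data offer no direct guide to the change. The expectation is therefore a step of a 1.2-fold lower number from compound 3 to compound 4 (0.07 log units; within the scatter) that remains within the scatter, in no firm direction. For compound 4 the estimated value in this assay is 14000 nM, with a range from 5000 nM to 40000 nM.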

Compound 4, half-maximal inhibitory concentration: > 60000 nM
Compound 4 ended at the assay's limit (the forecaster's own chance of this, stated with the estimate: 10%); middle value at least 4.2-fold (0.63 log units) from the limit.
By their numbers in this assay, from the lowest: compound 1; then compounds 3 and 2 (each within the scatter of the next). At a limit, above all of these: compound 4.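

In this assay, the exchange of hydrogen for fluoro on an aromatic carbon, ortho to a large group and meta to a large group, proves not to be silent: an at least 3.6-fold higher number from compound 3 to compound 4 (0.56 log units; beyond the scatter). The earlier steps shown here all concerned another position and left every number measurable, whereas this single fluoro atom takes compound 4 to the end of the measurable range. Compound 4 therefore gives a limit and not a number, so the true size of the step stays unknown: the limit of > 60000 nM in this assay, at which 1 of the 4 values shown sits.

The compounds shown leave open whether fluoro at this place would raise the number as sharply with the trifluoromethoxy group of compound 1 on the other ring. They also leave open whether a methoxy group or an amine at this place would be tolerated any better in this assay.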